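Hydroxy to Methoxy on an Indole Ketone Series

The source may report more compounds than this note shows. Statements on the series, on what has been measured and on what is new or still open speak of the compounds shown alone.

Measured compounds:
- compound 1, `O=C(Cc1cccnc1)c1cc2c(O)cccc2[nH]1`: "not active" (no number reported)
- compound 2, `COc1ccc2[nH]c(C(=O)Cc3cccnc3)cc2c1O`: 11%

Two compounds of this series have been examined in an in vitro assay on P815B cells for inhibition of Indoleamine 2,3-dioxygenase 1 (Mus musculus), tested at 20 uM; on this read-out lower numbers stand for less inhibition and higher numbers for more inhibition at the one concentration tested (going by the name of the read-out). Compound 1, carrying a free hydroxy group on its core, is reported in this assay as "not active" (no number reported), so no single number stands for it and its position on the scale is only that it showed no measurable inhibition. Compound 2, which carries both a methoxy and a hydroxy group, gives 11% in this assay, a figure that sits low on the read-out. Among the measured compounds shown here, no step between two measured compounds that differ in one place is available, so no measured change can be quoted.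

Compound 3, `COc1cccc2[nH]c(C(=O)Cc3cccnc3)cc12`, has not been measured. It differs from compound 1 by methyl in place of hydrogen on an oxygen on an aromatic ring. With compound 1 reported as not active, the step to compound 3 is expected to be small, either none beyond the scatter or at most a modest rise toward the low figure of compound 2. Compound 3 is therefore estimated at 8%, with a range from 0% to 22%, and it may well be reported as not active.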

Compound 3, a percentage reported as inhibition, at one concentration (the size of the read-out at that concentration, not a potency): "not active" (no number reported)
Compound 3 has no reported number here; there is nothing to compare the estimate with.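

In this assay compound 1 gives "not active" (no number reported) and compound 3 gives "not active" (no number reported) so no step can be read between them. Nothing shown here bears on this result. The compounds shown leave open whether the change from hydroxy to methoxy on the shared core alters inhibition at all, as neither compound has a number.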